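This account rests on a few compounds, and the source may have more. Where it says the series, first, only, none or still open, it means among the compounds named here.

Measured compounds:
- Compound 1 `Cc1ccc(/C=N/NC(=O)COc2cccc3ccccc23)cc1` gives 4.49 in a physicochemical assay for lipophilicity, measured as octanol-water partition; a higher number here means a more lipophilic compound, a lower number a more polar compound
- Compound 2 `O=C(COc1cccc2ccccc12)N/N=C/c1ccccc1` gives 4.02 in this assay
- Compound 3 `O=C(COc1cccc2ccccc12)N/N=C/c1ccc(Br)cc1` gives 4.81 in this assay

Compound 3 stands highest of the three in this assay, with the step of a number 0.32 log units higher from compound 1 to compound 3 (beyond the scatter) and the step of a number 0.79 log units higher from compound 2 to compound 3 (beyond the scatter) both beyond the scatter. Compound 4 `O=C(COc1cccc2ccccc12)N/N=C/c1cccc(Cl)c1` differs from compound 3 in one place: 3-chlorophenyl in place of 4-bromophenyl on a carbon with a double bond to nitrogen. Among the compounds with values here, no measured step exchanges one halogen for another, and none shows chloro at all. The step of a number 0.79 log units higher from compound 2 to compound 3 (beyond the scatter) is the nearest guide, showing how much a halogen on that ring raised the number over hydrogen. Compound 4 is therefore expected to stay close to compound 3, with a step of a number 0.16 log units lower from compound 3 to compound 4 (within the scatter) that lies within the scatter. Compound 4 is estimated at 4.65, between 4.35 and 4.95.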

Compound 4, partition coefficient: 4.54
For compound 4 the middle estimate is 0.11 log units above the measured one; the range from low to high includes it.
By their numbers in this assay, from the lowest: compound 2; then compounds 1, 4 and 3 (each within the scatter of the next, the first and the last beyond it).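

Against hydrogen, chloro on this ring also gives a clear rise in this assay, with a number 0.52 log units higher from compound 2 to compound 4 (beyond the scatter) in this read-out. The other two steps, a number 0.27 log units lower from compound 3 to compound 4 (within the scatter) and a number 0.05 log units higher from compound 1 to compound 4 (within the scatter), do not separate compound 4 from either neighbour, although compound 1 and compound 3 remain apart. No measurement at hand explains these numbers.

Going by these compounds, what 4-chlorophenyl or 3-bromophenyl would give remains open, so the choice of halogen and its place on the ring cannot yet be separated. An amine or a carboxylic acid on this ring also remains untested among the compounds shown.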